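Methoxy to ethoxy on a compound reported only as a limit

The source may report more compounds than this note shows. Statements on the series, on what has been measured and on what is new or still open speak of the compounds shown alone.

Compounds measured so far:
Compound 1 `CC1CC/C(=N\Nc2ccccc2Br)c2ncc(C(=O)O)c(=O)n21`; in a functional assay on the whole organism for inhibition, with Rattus norvegicus as the target (on this read-out lower numbers stand for an effect already at smaller amounts and higher numbers for an effect only at larger amounts of compound), compound 1 gives > 320 umol/kg, which is a limit of the assay and not a number.
Compound 2 `CC1CC/C(=N\Nc2ccccc2O)c2ncc(C(=O)O)c(=O)n21`; compound 2 gives > 100 umol/kg, again a limit.
Compound 3 `COc1ccccc1N/N=C1\CCC(C)n2c1ncc(C(=O)O)c2=O`; compound 3 gives > 1000 umol/kg, also a limit.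

Compound 3 therefore has no measured number, and the two other values are limits as well, so compound 3 cannot be placed above or below them. The three steps among the measured compounds, a step that the two limits leave unreadable from compound 1 to compound 2, a step that the two limits leave unreadable from compound 1 to compound 3 and a step that the two limits leave unreadable from compound 2 to compound 3, are all unreadable for the same reason.

Compound 4 `CCOc1ccccc1N/N=C1\CCC(C)n2c1ncc(C(=O)O)c2=O` differs from compound 3 by methyl in place of hydrogen on a saturated chain carbon bound to an oxygen on an aromatic ring. For the measured compounds named here, the only measured step touching this part of the molecule, the one from compound 2 to compound 3, gives no readable size, so no measured step bears on the new change. Nothing in the data points in either direction, and the expectation is no step beyond the scatter. Compound 4 is expected to be reported once more as a limit, at an estimated 1000 umol/kg, with a range from 300 umol/kg to 3000 umol/kg. The expected step from the limit of compound 3 is a number no higher from compound 3 to compound 4 (the limit leaves the size open).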

Compound 4, dose for 50% inhibition: > 1000 umol/kg
Compound 4: a limit, no number (the forecaster's own chance of this, stated with the estimate: 85%); the middle value lies on the limit itself.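

Compound 4 gives > 1000 umol/kg, which is a limit of the assay and not a number. The values of compound 1, compound 2 and compound 3 are limits too, so no new step can be read from compound 4 to any of them. The compounds shown leave open whether methoxy and ethoxy differ at all, and what dose of any compound would reach the read-out.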